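Trading an Aminophenyl for a Methylaminopropyl Side Chain

This account rests on a few compounds, and the source may have more. Where it says the series, first, only, none or still open, it means among the compounds named here.

Three compounds built on a shared core are shown, with one more awaiting measurement. Compound 1 `O=C(NCc1ccc(F)cc1)c1nc(Br)c2cccnc2c1NCCCNc1c(C(=O)NCc2ccc(F)cc2)nc(Br)c2cccnc12` has no result in a functional assay on MCF7 cells (Homo sapiens) for cytotoxicity, read by MTT assay, with a stated time of 72 h (a higher number here means a weaker inhibitor, a lower number a stronger inhibitor), its entry reading "not determined" (no result reported). For the measured compounds named here, compound 2 `Nc1ccc(Nc2c(C(=O)NCc3ccc(F)cc3)nc(Br)c3cccnc23)cc1` gives 4000 nM in this assay, and this is the only plain number among the values shown. Compound 3 `NCCCNc1c(C(=O)NCc2ccc(F)cc2)ncc2cccnc12` reaches only a limit of the assay in this assay, reported as > 10000 nM. So compound 2 stands as the single measured anchor. Beside it, one further value sits at the limit of > 10000 nM in this assay, at which 1 of the 3 values shown sits, and one entry carries no result at all.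

Compound 4 `CNCCCNc1c(C(=O)NCc2ccc(F)cc2)nc(Br)c2cccnc12` is the one to be measured. Its difference from compound 2 is 3-(methylamino)propyl in place of 4-aminophenyl on a nitrogen on an aromatic ring. Going by the values given here, no step between two measured compounds is available, so the size of this step can only be expected, not read off. Compound 3, which also lacks a ring on that nitrogen, is reported at > 10000 nM, a limit, and this points toward a weaker result rather than a stronger one. The step is expected to be a 2.3-fold higher number from compound 2 to compound 4 (0.35 log units; beyond the scatter), a loss beyond the scatter. Compound 4 is therefore expected to give 9000 nM in this assay, within a range from 3000 nM to 25000 nM, with a fair chance that only a limit is reported.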

Compound 4, half-maximal inhibitory concentration: > 10000 nM
Compound 4 gave a limit, no number; the forecaster's own chance of this, stated with the estimate: 40%; middle value at least 1.1-fold (0.04 log units) from the limit.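

For the compounds shown here, putting 3-(methylamino)propyl in place of 4-aminophenyl on this nitrogen gives the first step that can be read at this position: in this assay the change produces an at least 2.5-fold higher number from compound 2 to compound 4 (0.39 log units; beyond the scatter). That figure is a lower bound and not a full size, so the true loss on leaving the aromatic ring behind may be larger, though the data cannot say by how much. Compound 4 gives only a limit of the assay, and it now shares that limit with another compound, so the two cannot be ranked against each other: the limit of > 10000 nM in this assay, at which 2 of the 4 values shown sit.

The compounds shown do not separate the role of the ring from the role of the amine it carries, and a plain phenyl group or a 4-hydroxyphenyl group on the same nitrogen would help to pull those two apart. They also leave open whether a cyclic amine such as piperidine, or a longer chain ending in a primary amine, could bring a value on this core back into the measurable range.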